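Adding a Methoxy Group to Compound 1

The source may hold more compounds than are shown below. What is called first, only, known or untested is meant among the compounds shown, and "the series" means these compounds.

Among the compounds with values here, in a functional assay on MDA-MB-231 cells (Homo sapiens) for antiproliferative activity, read by MTT assay, with a stated time of 48 h (on this read-out lower numbers stand for stronger inhibition of growth and higher numbers for weaker inhibition of growth), compound 1 `CCCOC(=O)N1N=C(c2ccccc2)CC1c1cc(OC)c(OC)c(OC)c1` gives 14400 nM as the only true number so far. Compound 2 `COc1cc(C2CC(c3ccccc3)=NN2C(=O)OCc2ccccc2)cc(OC)c1OC` gives > 10000 nM as a limit of the assay and not a number. This makes a step that the limit leaves unreadable from compound 1 to compound 2 and it lies elsewhere in the molecule than the change followed here. Compound 3 `CCCOC(=O)N1N=C(c2ccc(OC)cc2)CC1c1cc(OC)c(OC)c(OC)c1` differs from compound 1 by methoxy in place of hydrogen on an aromatic carbon with methoxy in place of hydrogen on an aromatic carbon. Within the data shown here, with compound 1 at 14400 nM as the only anchor and no measured step at this place, no shift beyond the usual scatter is expected in either direction. The expected result is a 1.0-fold lower number from compound 1 to compound 3 (0.01 log units; within the scatter) as an estimate only. Compound 3 is therefore estimated at 14000 nM with 6000 nM to 30000 nM as its likely range.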

Compound 3, concentration for 50% growth inhibition: 20400 nM
For compound 3 the middle estimate is 1.5-fold (0.16 log units) below the measured one, and the stated range covers the measured number.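

In this assay, replacing phenyl with 4-methoxyphenyl gives a 1.4-fold higher number from compound 1 to compound 3 (0.15 log units; within the scatter). Within the data shown here, this is the first readable step, and it shows that hydrogen and methoxy at this position cannot be told apart on this read-out. Both compounds read at the weak end of the scale, near the point where the assay stops giving numbers: the limit of > 10000 nM in this assay, at which 1 of the 3 values shown sits.

One methoxy group says little about other groups at this position. As far as these compounds go, whether an amine, a carboxylic acid or a chlorine atom there would shift the number remains open.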